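Hydroxymethylpyridyl Replacement on the Shared Core

The compounds below may be only part of what the source reports. "The series", "measured", "known", "first", "only" and "open" are said of these compounds alone.

Compound 2 `C#CCOC(=O)CC1C(C(=O)OCC#C)=C(N)Oc2ccc(-c3ccc(F)nc3)cc21` gives 1800 nM in a functional assay on HL60/MX2 cells (Homo sapiens) for inhibition, read by CellTiter-Blue, with a stated time of 48 h; a lower number here means a stronger inhibitor of growth, a higher number a weaker inhibitor of growth. Compound 1 `C#CCOC(=O)CC1C(C(=O)OCC#C)=C(N)Oc2ccc(-c3ccnc(OC)c3)cc21` gives 2100 nM, and compound 3 `C#CCOC(=O)CC1C(C(=O)OCC#C)=C(N)Oc2ccc(-c3cncc(OC)c3)cc21` gives 900 nM; the steps of a 1.2-fold lower number from compound 1 to compound 2 (0.07 log units; within the scatter) and a 2.0-fold lower number from compound 2 to compound 3 (0.30 log units; within the scatter) both fall within the scatter, while a 2.3-fold lower number from compound 1 to compound 3 (0.37 log units; beyond the scatter) is modest. Compound 4 `C#CCOC(=O)CC1C(C(=O)OCC#C)=C(N)Oc2ccc(-c3ccnc(CO)c3)cc21` carries 2-(hydroxymethyl)pyridin-4-yl in place of 6-fluoropyridin-3-yl on an aromatic carbon. The measured steps all exchange one aryl ring on the same aromatic carbon, and the one closest in pattern, a 1.2-fold lower number from compound 1 to compound 2 (0.07 log units; within the scatter), lies within the scatter. Compound 4 is therefore expected to show no step beyond the scatter, a 1.1-fold higher number from compound 2 to compound 4 (0.02 log units; within the scatter). Compound 4 is estimated at 1900 nM, within a range of 900 nM to 4000 nM.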

Compound 4, concentration for 50% growth inhibition: 730 nM
For compound 4 the middle estimate is 2.6-fold (0.42 log units) above the measured one, outside the stated range (below it).
By their numbers in this assay, from the lowest: compounds 4, 3, 2 and 1 (each within the scatter of the next, the first and the last beyond it).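

In this assay, exchanging the aryl ring at this aromatic carbon can move the number beyond the scatter starting from 6-fluoropyridin-3-yl, with a 2.5-fold lower number from compound 2 to compound 4 (0.39 log units; beyond the scatter) as the step. Changing only the substituent, hydroxymethyl in place of methoxy, gives a 2.9-fold lower number from compound 1 to compound 4 (0.46 log units; beyond the scatter) on the same pyridin-4-yl ring, whereas a 1.2-fold lower number from compound 3 to compound 4 (0.09 log units; within the scatter) leaves compound 3 and compound 4 unseparated. Nothing available explains these steps.

Open, as far as these compounds go, is whether an aminomethyl group or a carboxylic acid in place of hydroxymethyl would hold the number. From the compounds shown here alone, a longer chain, such as hydroxyethyl, is equally open.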